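From 4-chlorophenyl to 4-isopropylphenyl on a shared core

The source may report more compounds than this note shows. Statements on the series, on what has been measured and on what is new or still open speak of the compounds shown alone.

Two compounds built on a shared core have so far been taken through a functional assay on A-375 cells (Homo sapiens) for antiproliferative activity, read by trypan blue exclusion and crystal violet staining, with a stated time of 72 h; on this read-out lower numbers stand for stronger inhibition and higher numbers for weaker inhibition. Compound 1 (`CCCCC(=O)NCc1ccc2cccnc2c1O`) gives "nd" (no result reported), so it offers no number for comparison. Compound 2 (`CCCC(=O)NC(c1ccc(Cl)cc1)c1cc(Cl)c2cccnc2c1O`) gives 120 nM, the only figure available, so it cannot yet be ranked against anything and serves simply as a starting point. The next compound, compound 3 (`CCCC(=O)NC(c1ccc(C(C)C)cc1)c1cc(Cl)c2cccnc2c1O`), differs from compound 2 in one place: isopropyl in place of chloro on an aromatic carbon, para to a large group, which turns 4-chlorophenyl into 4-isopropylphenyl (isopropyl in place of chloro on an aromatic carbon). For the measured compounds named here, no pair of measured compounds shows what a change like this does in this assay, so the expectation rests on a single value and stays loose. A small weakening seems the likeliest outcome, though a result within the usual scatter of compound 2 would be no surprise. The expected change is a 1.7-fold higher number from compound 2 to compound 3 (0.22 log units; within the scatter). For compound 3 the estimate is 200 nM, with an expected range from 60 nM to 700 nM.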

Compound 3, half-maximal inhibitory concentration: 120 nM
The estimate for compound 3 lay 1.7-fold (0.22 log units) above the measured number, and the stated range covers the measured number.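

In this assay, for the compounds shown here, there is no change at the digits printed from compound 2 to compound 3 (within the scatter), the first step in this small set that can be read at all. At this place on the aromatic ring, para to a large group, chloro can therefore give way to isopropyl, a group of three heavy atoms instead of one, with no measurable cost in this pair, so the position accepts at least these two groups, neither of which carries a net charge. Nothing available explains why the two groups match here, and the result has to stand as an observation without a cause.

On these data alone, a single step at a single place says nothing yet about groups of another kind, so it remains open whether an amine, a carboxylic acid or a longer chain such as hexyl would fit at this position as well as chloro and isopropyl do. As far as these compounds go, it also remains open whether the same swap would give the same result with a different amide chain on the shared core, or with the other chloro on the core replaced.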